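Cytotoxicity Limits for Two Amides and an Expected Third

The source may report more compounds than this note shows. Statements on the series, on what has been measured and on what is new or still open speak of the compounds shown alone.

Compound 1 `CC(C)N(Cc1cccc(OCCCCCC(=O)O)c1)C(=O)c1ccc(-c2cccc(Oc3ccccc3)c2)cc1` gives > 18700 nM in an ADME assay on Raji cells (Homo sapiens) for cytotoxicity, read by CellTiter-Glo and resazurin assay, with a stated time of 72 h; a lower number here means that less compound is needed, a higher number that more compound is needed for the effect.
Compound 2 `CCOC(=O)CCCCCOc1cccc(CN(C(=O)c2ccc(-c3ccc(C(C)=O)s3)cc2)C(C)C)c1` gives > 26000 nM in this assay.

Neither number is a measured value. For compound 1 the reading is the limit of > 18700 nM in this assay, at which 1 of the 2 values shown sits. Among the compounds with values here, for compound 2 the reading is the limit of > 26000 nM in this assay, at which 1 of the 2 values shown sits, so compound 2 stands at a limit, as does the only other value shown, and no ordering between the two compounds can be drawn.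

Compound 3 `CCOC(=O)CCCCCOc1cccc(CN(C(=O)c2ccc(-c3cccc(S(C)(=O)=O)c3)cc2)C(C)C)c1` has not been measured. Its change from compound 2 is 3-(methylsulfonyl)phenyl in place of 5-acetylthiophen-2-yl on an aromatic carbon. Within the data shown here, no measured pair of compounds shows a step of this kind, so nothing tells how large its effect might be. With both known values sitting at limits, compound 3 is expected to reach only a limit as well, and the expected step that the limit leaves unreadable from compound 2 to compound 3 should stay within the scatter. Compound 3 is therefore estimated at 30000 nM, with a range from 12000 nM to 100000 nM.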

Compound 3, half-maximal effective concentration: > 26000 nM
Compound 3 ended at the assay's limit; the forecaster's own chance of this, stated with the estimate: 85%; the middle value is on the limit's open side.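

Compound 2 and compound 3 both end at a limit rather than at a measured number, so no step between them can be read in this assay: the limit of > 26000 nM in this assay, at which 2 of the 3 values shown sit.

The compounds shown leave open whether 3-(methylsulfonyl)phenyl in place of 5-acetylthiophen-2-yl changes cytotoxicity at all, and at what concentration any of the three would reach the half-maximal effect.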